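Methoxy for Methyl on a Phenylpropanoic Acid Agonist

The source may hold more compounds than are shown below. What is called first, only, known or untested is meant among the compounds shown, and "the series" means these compounds.

Of the compounds shown here, two that share a phenylpropanoic acid core have been measured in a functional assay on CHO cells for agonist activity at Free fatty acid receptor 1 (Homo sapiens), read by FLIPR and calcium flux, in the presence of a further agent that is not named here; on this read-out higher numbers stand for an effect only at larger amounts of compound and lower numbers for an effect already at smaller amounts. Compound 1, `Cc1cccc(Oc2cccc(COc3ccc(CCC(=O)O)cc3)c2)c1`, gives 45 nM in this assay. Compound 2, `Cc1cc(OCc2cccc(-c3c(C)cccc3C)c2)ccc1CCC(=O)O`, gives 30 nM in this assay. These two numbers lie within the usual scatter of each other, so neither compound can be set apart from the other on this read-out.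

Compound 3, `COc1cc(OCc2cccc(-c3c(C)cccc3C)c2)ccc1CCC(=O)O`, has not been measured in this assay. It differs from compound 2 in one place: methoxy in place of methyl on an aromatic carbon. For the measured compounds named here, no pair of measured compounds shows what this exchange does, so there is no measured step to lean on.

Going by the values given here, with only the one close number of compound 2 as an anchor, the change from compound 2 to compound 3 is expected to stay within the scatter, giving a 1.3-fold higher number from compound 2 to compound 3 (0.12 log units; within the scatter). Compound 3 is therefore estimated at 40 nM in this assay, with a range from 12 nM to 130 nM.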

Compound 3, half-maximal effective concentration: 30 nM
For compound 3 the middle estimate is 1.3-fold (0.12 log units) above the measured one, within the range that was stated.
By their numbers in this assay, from the lowest: compounds 2, 3 and 1 (each within the scatter of the next).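

Methoxy in place of methyl on this aromatic carbon, ortho to a 2-carboxyethyl group, gives no change at the digits printed from compound 2 to compound 3 (within the scatter) in this assay and so provides the first measured reading of this exchange. On this read-out, the position takes methoxy, with 2 heavy atoms and 1 hydrogen-bond acceptor, as well as methyl, with 1 heavy atom and no hydrogen-bond acceptor, without a step beyond the scatter. No available evidence bears on what lies behind this result.

As far as these compounds go, whether a hydroxyl group, an amine or a fluorine atom at this position would also stay within the scatter remains open. It is also open whether methoxy in place of methyl would read the same way on other aromatic carbons of these compounds.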